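This account rests on a few compounds, and the source may have more. Where it says the series, first, only, none or still open, it means among the compounds named here.

Compound 1 (`Cc1ccccc1C(=O)N(C(=S)OCCN1C(=O)c2ccccc2C1=O)c1ccc(Cl)cc1`) gives 21000 nM 
Compound 2 (`Cc1ccc(C(=O)N(C(=S)OCCN2C(=O)c3ccccc3C2=O)c2ccc(Cl)cc2)cc1`) gives > 100000 nM as a limit
Compound 3 (`O=C1c2ccccc2C(=O)N1CCOC(=S)N(C(=O)c1cccc(Cl)c1Cl)c1ccc(Cl)cc1`) gives 54000 nM 

In an ADME assay on MT4 cells (Homo sapiens) for cytotoxicity, read by MTT assay (a higher number here means that more compound is tolerated, a lower number that less compound is tolerated), compound 3 at 54000 nM holds the higher of the two exact numbers, and the gap is a 2.6-fold higher number from compound 1 to compound 3 (0.41 log units; beyond the scatter) in this read-out. Compound 2 has > 100000 nM as its entry, which is a limit of the assay and not a number.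

Compound 4 (`O=C1c2ccccc2C(=O)N1CCOC(=S)N(C(=O)c1ccc([N+](=O)[O-])cc1Cl)c1ccc(Cl)cc1`) has not yet been measured. Its change from compound 3 is 2-chloro-4-nitrophenyl in place of 2,3-dichlorophenyl on a carbonyl carbon and amounts to 2-chloro-4-nitrophenyl in place of 2,3-dichlorophenyl on a carbonyl carbon.

Three measured steps swap the group at this same place. Besides the gap already given, they are an at least 4.7-fold higher number from compound 1 to compound 2 (0.67 log units; beyond the scatter) and an at least 1.8-fold lower number from compound 2 to compound 3 (0.26 log units; that floor lies within the scatter) in the same read-out. These steps are modest and run in both directions, so they set no clear direction for the new group, and no step beyond the scatter is expected in this assay here. The estimated step is a 1.1-fold lower number from compound 3 to compound 4 (0.03 log units; within the scatter) and it would stay within the scatter. For compound 4 the expected value is 50000 nM with an estimated range from 20000 nM to 100000 nM in this read-out.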

Compound 4, half-maximal cytotoxic concentration: 19000 nM
The estimate for compound 4 lay 2.6-fold (0.42 log units) above the measured number; measured number below the stated range.
By their numbers in this assay, from the lowest: compounds 4 and 1 (each within the scatter of the next); then compound 3. At a limit, above all of these: compound 2.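

In this assay the swap on the carbonyl carbon gives a 2.8-fold lower number from compound 3 to compound 4 (0.45 log units; beyond the scatter) and so shows that 2-chloro-4-nitrophenyl does not keep the higher number of the 2,3-dichlorophenyl compound. With a 1.1-fold lower number from compound 1 to compound 4 (0.04 log units; within the scatter) as the step between them, two different groups, 2-methylphenyl and 2-chloro-4-nitrophenyl, now share the low end of the series, so that low end is not tied to a single group. The remaining step is an at least 5.2-fold lower number from compound 2 to compound 4 (0.72 log units; beyond the scatter) and gives only a floor because one of its ends is a limit of the assay and not a number: the limit of > 100000 nM in this assay, at which 1 of the 4 values shown sits.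

What the nitro group does on its own stays open, as no compound shown has a phenyl ring carrying only that group. Also open, from the compounds shown here alone, is how an amine or a carboxylic acid on this ring would read in this assay when set against these four compounds.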